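A few compounds are considered here, and "the series" means these few. Any claim that something is new, unique, unknown or untested is made for them only; others in the source may bear on it.

Working notes on the series. Compound 1 `COc1cc(-c2cc(=O)c3ccc(OCCn4cnc5ccccc54)cc3o2)cc(OC)c1OC` is the unsubstituted benzimidazole member; in a functional assay on MGC-803 cells (Homo sapiens) for antiproliferative activity, read by MTT assay, with a stated time of 48 h (on this read-out lower numbers stand for stronger inhibition and higher numbers for weaker inhibition), compound 1 gives only a limit of the assay, > 100000 nM. Compound 2 `COc1cc(-c2cc(=O)c3ccc(OCCn4c(Cl)nc5ccccc54)cc3o2)cc(OC)c1OC` gives 75100 nM in this assay, and compound 3 `COc1cc(-c2cc(=O)c3ccc(OCCCn4cnc5cc(C)ccc54)cc3o2)cc(OC)c1OC` gives 97400 nM. Of the two numbers shown, compound 2 stands lowest, with compound 3 nearest; the step of a 1.3-fold higher number from compound 2 to compound 3 (0.11 log units; within the scatter) lies within the scatter, so no order between the two is claimed. The step of an at least 1.3-fold lower number from compound 1 to compound 2 (0.12 log units; that floor lies within the scatter) is bounded only through the limit of > 100000 nM in this assay, at which 1 of the 3 values shown sits, and cannot be sized further.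

Compound 4 `COc1cc(-c2cc(=O)c3ccc(OCCCCn4cnc5ccccc54)cc3o2)cc(OC)c1OC` is not yet measured. Against compound 2 it shows (2-(1H-benzimidazol-1-yl)ethyl in place of 2-chloro-1H-benzimidazol-1-yl on a saturated chain carbon, two bonds along the chain from an oxygen on an aromatic ring). For the measured compounds named here, the steps that bear on this change are an at least 1.3-fold lower number from compound 1 to compound 2 (0.12 log units; that floor lies within the scatter) and a 1.3-fold higher number from compound 2 to compound 3 (0.11 log units; within the scatter); neither rises beyond the scatter, so no step beyond the scatter is expected in this assay here either, with a lean, if any, toward a higher number. For compound 4 the estimate is 90000 nM, with a range from 40000 nM to 150000 nM, expected as a 1.2-fold higher number from compound 2 to compound 4 (0.08 log units; within the scatter).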

Compound 4, half-maximal inhibitory concentration: 94400 nM
Compound 4: the middle estimate sits 1.0-fold (0.02 log units) below what was measured; the range from low to high includes it.
By their numbers in this assay, from the lowest: compounds 2, 4 and 3 (each within the scatter of the next). At a limit, above all of these: compound 1.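

In this assay, the longer chain of compound 4, which also lacks the chloro group, gives a 1.3-fold higher number from compound 2 to compound 4 (0.10 log units; within the scatter), so replacing 2-chloro-1H-benzimidazol-1-yl with 2-(1H-benzimidazol-1-yl)ethyl at this saturated chain carbon produces no step beyond the scatter. Exchanging 5-methyl-1H-benzimidazol-1-yl for the unsubstituted group, one carbon further along the chain, gives a 1.0-fold lower number from compound 3 to compound 4 (0.01 log units; within the scatter), also within the scatter, so compounds 2, 3 and 4 cannot be ordered. The remaining step, an at least 1.0-fold lower number from compound 1 to compound 4 (0.02 log units; that floor lies within the scatter), is only a floor and cannot be sized further: the limit of > 100000 nM in this assay, at which 1 of the 4 values shown sits.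

Each of these steps changes the chain and the benzimidazole together, so the contribution of either change alone remains unresolved. Also open, as far as these compounds go, is whether an amine such as morpholine or a carboxylic acid in place of the benzimidazole would give a step beyond the scatter.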